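The compounds below may be only part of what the source reports. "The series", "measured", "known", "first", "only" and "open" are said of these compounds alone.

The three measured compounds in a physicochemical assay for solubility, read by HPLC, in phosphate buffer, with a stated time of 4 h, at pH 7.4 (on this read-out higher numbers stand for higher solubility and lower numbers for lower solubility), are:

Compound 1, `Cc1cc(/C=C/C#N)cc(C)c1Oc1cc(Nc2ccc(C#N)cc2)c(N)cc1C(=O)NN`, with 2.4 ug/mL
Compound 2, `Cc1cc(/C=C/C#N)cc(C)c1Oc1cc(Nc2ccc(C#N)cc2)c(N)cc1C(=O)NCCC(F)F`, with 6.59 ug/mL
Compound 3, `Cc1cc(/C=C/C#N)cc(C)c1Oc1cc(Nc2ccc(C#N)cc2)c(N)cc1C(=O)N1CC1`, with 1.2 ug/mL

Compound 3 holds the lowest of the three numbers in this assay. Its nearest neighbour is compound 1, and the step of a 2.0-fold lower number from compound 1 to compound 3 (0.30 log units; within the scatter) lies within the scatter, so the two cannot be ordered. Compound 2 is the furthest away, and the step of a 5.5-fold lower number from compound 2 to compound 3 (0.74 log units; beyond the scatter) is beyond the scatter, though still modest in size.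

Compound 4, `CNC(=O)c1cc(N)c(Nc2ccc(C#N)cc2)cc1Oc1c(C)cc(/C=C/C#N)cc1C`, differs from compound 3 in one place: methylamino in place of aziridin-1-yl on a carbonyl carbon. Both measured steps into compound 3 bear on this change, since each replaces an amide substituent bearing a nitrogen-hydrogen donor with the ring-closed aziridin-1-yl, and both run downward, one within the scatter and one modestly beyond it. Reversing that direction with a small methylamino group, compound 4 is expected to show a modest rise in this assay, a 2.3-fold higher number from compound 3 to compound 4 (0.37 log units; beyond the scatter), most likely landing between the numbers of compound 1 and compound 2. Compound 4 is therefore estimated at 2.8 ug/mL, with a range from 1.1 ug/mL to 7 ug/mL.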

Compound 4, solubility: 8.28 ug/mL
Compound 4: middle estimate off by 3.0-fold (0.47 log units), on the low side; the measured number lies above the stated range.
By their numbers in this assay, from the lowest: compounds 3 and 1 (each within the scatter of the next); then compounds 2 and 4 (each within the scatter of the next).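

In this assay, the open-chain methylamino in place of aziridin-1-yl on a carbonyl carbon gives a clear change (a 6.9-fold higher number from compound 3 to compound 4 (0.84 log units; beyond the scatter)), so the low number of compound 3 is not shared by every small group at this place, while compound 1, with its amino group, remains within the scatter of compound 3 and goes against any simple rule that open-chain groups read higher. The chain on the amide-type nitrogen can also be cut back to methyl with no readable change, as hydrogen in place of 2,2-difluoroethyl shows (a 1.3-fold higher number from compound 2 to compound 4 (0.10 log units; within the scatter)), whereas methyl in place of amino on that same nitrogen does give a readable change (a 3.5-fold higher number from compound 1 to compound 4 (0.54 log units; beyond the scatter)). Nothing available explains why these numbers move as they do. The compounds shown do not separate closing the ring from losing the amide hydrogen, a question that dimethylamino at this carbonyl carbon would address. Going by these compounds, how a chain ending in an amine or a carboxylic acid would read in this assay also remains open.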